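The source may report more compounds than this note shows. Statements on the series, on what has been measured and on what is new or still open speak of the compounds shown alone.

Series notes, step from compound 3 to compound 4.

Compound 3 `CCC(C)(C)Cc1c[nH]c(CCc2ccc(-n3cncn3)cc2)n1` gives 340 nM in an in vitro assay on CHO cells for displacement of a labelled ligand from Bombesin receptor subtype-3 (Homo sapiens), read by scintillation counting, with a stated time of 2 h (a higher number here means a weaker inhibitor, a lower number a stronger inhibitor), and stands highest of the three numbers measured. Compound 1 `CCC(C)(C)Cc1c[nH]c(CCc2ccc(-n3cccn3)cc2)n1` gives 33 nM in this assay, and compound 2 `CCC(C)(C)Cc1c[nH]c(CCc2ccc(-c3cccc(N)n3)cc2)n1` gives 7.3 nM. The steps into compound 3 are both large and beyond the scatter: a 10-fold higher number from compound 1 to compound 3 (1.01 log units; beyond the scatter) and a 47-fold higher number from compound 2 to compound 3 (1.67 log units; beyond the scatter). The step of a 4.5-fold lower number from compound 1 to compound 2 (0.66 log units; beyond the scatter) is modest.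

Compound 4 `CCC(C)(C)Cc1c[nH]c(CCc2ccc(-c3cccnc3C(=O)O)cc2)n1` carries the change (2-carboxypyridin-3-yl in place of 1H-1,2,4-triazol-1-yl on an aromatic carbon). Both steps ending at compound 3 bear on it, since each replaces a six- or five-membered group in the same position with 1H-1,2,4-triazol-1-yl and each raises the number; the reverse move away from the triazole, toward a six-membered ring as in compound 2, is therefore expected to lower the number in this assay. Among the measured compounds shown here, the carboxylic acid has no measured precedent here, so the expected step is kept below the size of a 47-fold higher number from compound 2 to compound 3 (1.67 log units; beyond the scatter). Compound 4 is estimated at 45 nM, range 8 nM to 250 nM, an expected step of a 7.6-fold lower number from compound 3 to compound 4 (0.88 log units; beyond the scatter).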

Compound 4, half-maximal inhibitory concentration: 560 nM
Compound 4: the middle estimate sits 12-fold (1.09 log units) below what was measured, and the stated range ends below it.
By their numbers in this assay, from the lowest: compound 2; then compound 1; then compounds 3 and 4 (each within the scatter of the next).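

In this assay, a six-membered aromatic ring on this aromatic carbon does not by itself lower the number: replacing 1H-1,2,4-triazol-1-yl with 2-carboxypyridin-3-yl gives a 1.6-fold higher number from compound 3 to compound 4 (0.22 log units; within the scatter) and so leaves the two groups within the scatter of each other. Ring size alone does not order these groups, since both compound 2 and compound 4 carry a six-membered aromatic ring with one hetero atom, yet the data show a 77-fold higher number from compound 2 to compound 4 (1.88 log units; beyond the scatter) and, against the five-membered 1H-pyrazol-1-yl, a 17-fold higher number from compound 1 to compound 4 (1.23 log units; beyond the scatter) as well. No measurement at hand accounts for this result.

Still open, as far as these compounds go, is whether the carboxylic acid or the attachment of its ring sets the gap to compound 2. A methyl ester or a primary amide in place of the carboxylic acid, or an amine on the same ring, would help separate the two.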